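The source may report more compounds than this note shows. Statements on the series, on what has been measured and on what is new or still open speak of the compounds shown alone.

In an ADME assay on the whole organism (Rattus norvegicus, strain Sprague-Dawley) for pharmacokinetics, read by LC-MS (on this read-out higher numbers stand for wider distribution into tissues and lower numbers for narrower distribution), compound 2 (`N#Cc1ccc(S(=O)(=O)N2C[C@H](S(=O)(=O)c3ccc(Cl)cc3)[C@](O)(CO)C2)c(Cl)c1`) gives 4.5 L/kg. Compound 3 (`N#Cc1ccc(S(=O)(=O)N2C[C@H](S(=O)(=O)c3ccc(Cl)cc3)[C@](O)(CO)C2)cn1`) gives 4.1 L/kg, within the scatter of compound 2, while compound 1 (`N#Cc1ccc(S(=O)(=O)[C@H]2CN(S(=O)(=O)c3ccc(C#N)cc3Cl)C[C@@]2(O)CO)cc1`) gives a lower 2.2 L/kg. Compound 4 (`N#Cc1ccc(S(=O)(=O)N2C[C@H](S(=O)(=O)c3ccc(Cl)cn3)[C@](O)(CO)C2)c(Cl)c1`) differs from compound 2 in one group: 5-chloropyridin-2-yl in place of 4-chlorophenyl on a sulfonyl sulfur. Thus 5-chloropyridin-2-yl stands in place of 4-chlorophenyl on a sulfonyl sulfur. Within the data shown here, two measured steps bear on this. With 6-cyanopyridin-3-yl in place of 2-chloro-4-cyanophenyl on a sulfonyl sulfur, a 1.1-fold lower number from compound 2 to compound 3 (0.04 log units; within the scatter). With chloro in place of cyano on an aromatic carbon, a 2.0-fold higher number from compound 1 to compound 2 (0.31 log units; beyond the scatter). Neither step makes the same exchange, so only a small decrease is expected in this assay. The estimated change is a 1.2-fold lower number from compound 2 to compound 4 (0.09 log units; within the scatter). For compound 4 the estimated value is 3.7 L/kg, with an expected range of 2.2 L/kg to 6 L/kg.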

Compound 4, volume of distribution at steady state: 2 L/kg
Compound 4: middle estimate off by 1.9-fold (0.27 log units), on the high side, and the stated range ends above it.
By their numbers in this assay, from the lowest: compounds 4, 1, 3 and 2 (each within the scatter of the next, the first and the last beyond it).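

In this assay, among these compounds, the ring at this sulfonyl sulfur proves sensitive: the single exchange of 4-chlorophenyl for 5-chloropyridin-2-yl gives a 2.3-fold lower number from compound 2 to compound 4 (0.35 log units; beyond the scatter), whereas the earlier exchange for a pyridine ring, 6-cyanopyridin-3-yl at the other sulfonyl sulfur, stayed within the scatter. The 4-cyanophenyl group of compound 1 and the 5-chloropyridin-2-yl group give closely matched results, with a 1.1-fold lower number from compound 1 to compound 4 (0.04 log units; within the scatter), so two different replacements of 4-chlorophenyl land together. No evidence accounts for this step. Going by these compounds, whether a pyrimidine ring or a 5-fluoropyridin-2-yl group at this position would behave like compound 4 stays open.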